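A few compounds are considered here, and "the series" means these few. Any claim that something is new, unique, unknown or untested is made for them only; others in the source may bear on it.

Compound 2 `Fc1ccc(C2(c3ccc(F)cc3)CNC(c3cccc(F)c3)=N2)cc1` carries a 3-fluorophenyl group on a carbon with a double bond to nitrogen of its five-membered core. In an assay on LM cells for displacement of a labelled ligand from Neuropeptide Y receptor type 5 (Homo sapiens) (on this read-out lower numbers stand for stronger inhibition and higher numbers for weaker inhibition), compound 2 gives 10 nM, the lowest of the three numbers obtained so far. Compound 1 `Fc1ccc(C2(c3ccc(F)cc3)CNC(c3ccccc3)=N2)cc1`, which carries a plain phenyl on that carbon, gives 32 nM in this assay, so the step is a 3.2-fold lower number from compound 1 to compound 2 (0.51 log units; beyond the scatter). Compound 3 `Fc1ccc(C2(c3ccc(F)cc3)CNC(c3ccccn3)=N2)cc1`, which carries pyridin-2-yl on that carbon, gives 160 nM in this assay, with steps of a 5.0-fold higher number from compound 1 to compound 3 (0.70 log units; beyond the scatter) and a 16-fold higher number from compound 2 to compound 3 (1.20 log units; beyond the scatter).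

Compound 4 `N#Cc1cc(C2=NC(c3ccc(F)cc3)(c3ccc(F)cc3)CN2)ccn1` has not yet been measured. Its change from compound 2 is 2-cyanopyridin-4-yl in place of 3-fluorophenyl on a carbon with a double bond to nitrogen.

Within the data shown here, the only measured steps that put a six-membered aromatic ring with a hetero atom on this carbon are those to compound 3, and both raised the number, the larger being a 16-fold higher number from compound 2 to compound 3 (1.20 log units; beyond the scatter). Compound 4 brings a different such ring, bearing a nitrile, so a weaker number than compound 2 is expected, roughly an 8.0-fold higher number from compound 2 to compound 4 (0.90 log units; beyond the scatter). Compound 4 is therefore estimated at 80 nM, within a range of 25 nM to 250 nM.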

Compound 4, half-maximal inhibitory concentration: 4.8 nM
Beside the measured number, compound 4's estimate is 17-fold (1.22 log units) above it; the whole stated range lies above it.
By their numbers in this assay, from the lowest: compound 4; then compound 2; then compound 1; then compound 3.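

Until now the only ring with a hetero atom on this carbon, pyridin-2-yl, had raised the number, but 2-cyanopyridin-4-yl shows that such a ring can also give a lower number than either carbon-only ring (a 6.7-fold lower number from compound 1 to compound 4 (0.82 log units; beyond the scatter); a 2.1-fold lower number from compound 2 to compound 4 (0.32 log units; beyond the scatter)). The two rings with a hetero atom lie far apart in this assay (a 33-fold lower number from compound 3 to compound 4 (1.52 log units; beyond the scatter)), so at this position a ring nitrogen alone does not settle the outcome. No supporting evidence is available to explain these differences.

On these data alone, the nitrile and the place of the ring nitrogen change together from compound 3 to compound 4, so their separate contributions remain open. A plain pyridin-4-yl or a 3-cyanophenyl group on this carbon would help separate them, and an amine or a carboxylic acid in place of the nitrile remains an open question.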